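Swapping a Pyridine for a Thiophene at the Biaryl End

A few compounds are considered here, and "the series" means these few. Any claim that something is new, unique, unknown or untested is made for them only; others in the source may bear on it.

Compound 1, `O=C(CCc1ccc(-c2ccc(Cl)cc2)cc1)N1CCCC1`, gives 48600 nM in an assay on HEK293 cells for inhibition of N-acylethanolamine-hydrolyzing acid amidase (Rattus norvegicus), read by LC-MS, with a stated time of 30 min; on this read-out higher numbers stand for weaker inhibition and lower numbers for stronger inhibition.
Compound 2, `O=C(CCc1ccc(-c2cccnc2)cc1)N1CCCC1`, gives > 100000 nM in this assay, which is a limit of the assay rather than a number (the limit of > 100000 nM in this assay, at which 1 of the 2 values shown sits).

Compound 2 therefore stands at the weak end of what has been measured: the step of an at least 2.0-fold higher number from compound 1 to compound 2 (0.31 log units; beyond the scatter) is all that is known about it, and only as a lower bound. Compound 3, `O=C(CCc1ccc(-c2cccs2)cc1)N1CCCC1`, differs from compound 2 by thiophen-2-yl in place of pyridin-3-yl on an aromatic carbon. Going by the values given here, no measured step covers the thiophen-2-yl group itself; the one measured step, an at least 2.0-fold higher number from compound 1 to compound 2 (0.31 log units; beyond the scatter), concerns the same attachment point but a different pair of groups, so it bears on this change only indirectly. Among the compounds with values here, because the pyridin-3-yl group is the only feature that separates compound 2 from compound 1 in an at least 2.0-fold higher number from compound 1 to compound 2 (0.31 log units; beyond the scatter), removing it is expected to bring the number back toward the measured range. Compound 3 is expected to give about 70000 nM, within 25000 nM to 200000 nM. The expected step is an at least 1.4-fold lower number from compound 2 to compound 3 (0.15 log units; that floor lies within the scatter), with a real chance that only a limit is returned.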

Compound 3, half-maximal inhibitory concentration: > 100000 nM
Compound 3: no number, only a limit; the forecaster's own chance of this, stated with the estimate: 45%; middle value at least 1.4-fold (0.15 log units) from the limit.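

Replacing the 4-chlorophenyl group with thiophen-2-yl gives an at least 2.0-fold higher number from compound 1 to compound 3 (0.31 log units; beyond the scatter), so a five-membered aromatic ring at this position also leaves the readable range, as the six-membered pyridin-3-yl did. Compound 3 thus joins compound 2 at the limit of the assay, and of the compounds shown only compound 1 keeps a measured number: the limit of > 100000 nM in this assay, at which 2 of the 3 values shown sit. The step from compound 2 to compound 3 cannot be read, and the pyridin-3-yl and thiophen-2-yl groups remain unranked against each other.

As far as these compounds go, it remains open whether the chlorine atom or the phenyl ring of the 4-chlorophenyl group accounts for compound 1 giving a number, which a plain phenyl or a 4-fluorophenyl group would help to separate. From the compounds shown here alone, how far compound 2 and compound 3 lie past the limit also stays unknown.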